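Pyrazolylacetamide growth on the shared core of compound 1

The compounds below may be only part of what the source reports. "The series", "measured", "known", "first", "only" and "open" are said of these compounds alone.

Compound 1 `C[C@@H]1CN(c2sc(C(F)(F)F)nc2-c2nc3ccccc3[nH]2)CCN1C(=O)Cn1cccn1` sets the upper end of the two numbers seen so far in a functional assay on CHO-K1 cells for antagonist activity at C-X-C chemokine receptor type 3 (Homo sapiens), read by FLIPR, with a stated time of 10 min, in the presence of a further agent that is not named here; on this read-out lower numbers stand for stronger inhibition and higher numbers for weaker inhibition: compound 1 gives 13 nM. Compound 2 `C[C@@H]1CN(c2sc(C(F)(F)F)nc2-c2nc3ccc(CO)cc3[nH]2)CCN1C(=O)Cn1cnc2cccnc21`, which carries a larger heteroaromatic ring on the acetamide chain and a hydroxymethyl group on the benzimidazole-type part of the core, gives 4.6 nM in this assay, a lower number than compound 1 and a gap that lies beyond the usual scatter; as compound 2 differs from compound 1 in two places, no single-point step can be read from it.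

Compound 3 `Cc1nn(CC(=O)N2CCN(c3sc(C(F)(F)F)nc3-c3nc4ccccc4[nH]3)C[C@H]2C)cc1CN(C)C` differs from compound 1 in one place: 4-((dimethylamino)methyl)-3-methyl-1H-pyrazol-1-yl in place of 1H-pyrazol-1-yl on a saturated chain carbon bound to a carbonyl carbon. Among the measured compounds shown here, no measured step matches this change. A small gain or no change beyond the scatter is expected, the step from a 1.6-fold lower number from compound 1 to compound 3 (0.21 log units; within the scatter) being the estimate. Compound 3 is therefore expected to give about 8 nM in this assay, within 3 nM to 25 nM.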

Compound 3, half-maximal inhibitory concentration: 2.7 nM
The estimate for compound 3 lay 3.0-fold (0.47 log units) above the measured number, and the stated range ends above it.
By their numbers in this assay, from the lowest: compounds 3 and 2 (each within the scatter of the next); then compound 1.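

In this assay, among the compounds shown here, the change from 1H-pyrazol-1-yl to 4-((dimethylamino)methyl)-3-methyl-1H-pyrazol-1-yl on a saturated chain carbon bound to a carbonyl carbon provides the first single-place step, with a 4.8-fold lower number from compound 1 to compound 3 (0.68 log units; beyond the scatter) at this position. The position therefore accepts a group of 10 heavy atoms in place of one of 5, and the number falls rather than rises. Nothing available accounts for this step.

From the compounds shown here alone, the step adds the methyl and the (dimethylamino)methyl groups together, so the contribution of each remains open. Going by these compounds, it is also open whether a carboxylic acid or a morpholinomethyl group in place of the (dimethylamino)methyl group would keep a number of this size.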